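Chloro removal on the fused ring, second occurrence in series

The source may report more compounds than this note shows. Statements on the series, on what has been measured and on what is new or still open speak of the compounds shown alone.

Compound 1 `Cc1nn2c(-c3nc4cc(Cl)ccc4[nH]3)c(-c3ccccc3)nc2s1`, compound 2 `Cc1nn2c(-c3nc4ccccc4[nH]3)c(-c3ccccc3)nc2s1` and compound 3 `Cc1nn2c(-c3nc4cc(Cl)ccc4[nH]3)c(-c3ccc(F)cc3)nc2s1` have been measured in a functional assay on DU-145 cells (Homo sapiens) for antiproliferative activity, read by MTT assay; a higher number here means a weaker inhibitor, a lower number a stronger inhibitor; compound 4 `Cc1nn2c(-c3nc4ccccc4[nH]3)c(-c3ccc(F)cc3)nc2s1` has not. In this assay compound 1 gives 25100 nM and compound 3 gives 14400 nM. Compound 2 reaches only a limit of this assay, > 30000 nM, which is not a number. The two cores differ by fluoro in place of hydrogen on an aromatic carbon, and that step, a 1.7-fold lower number from compound 1 to compound 3 (0.24 log units; within the scatter), lies within the scatter.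

The change from compound 1 to compound 2 is hydrogen in place of chloro on an aromatic carbon, and it gave an at least 1.1-fold higher number from compound 1 to compound 2 (0.07 log units; that floor lies within the scatter), a floor set by the limit of > 30000 nM in this assay, at which 1 of the 3 values shown sits. Compound 4 differs from compound 3 by hydrogen in place of chloro on an aromatic carbon, the same change, made on the core of compound 3 instead of the core of compound 1; it occurs twice among these compounds.

For compound 4 the expected step is a 1.9-fold higher number from compound 3 to compound 4 (0.29 log units; within the scatter), resting on the measured at least 1.1-fold higher number from compound 1 to compound 2 (0.07 log units; that floor lies within the scatter). Since compound 2 sat at the limit, compound 4 may also be reported only as a limit. Compound 4 is estimated at 28000 nM, with a range of 14000 nM to 60000 nM.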

Compound 4, half-maximal inhibitory concentration: > 30000 nM
Compound 4: only a limit was reported (the forecaster's own chance of this, stated with the estimate: 50%); at least 1.0-fold (0.02 log units) between middle value and limit.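

In this assay, hydrogen in place of chloro on the fluoro-bearing core gave an at least 2.0-fold higher number from compound 3 to compound 4 (0.31 log units; beyond the scatter), a floor set by a limit of the assay rather than a measured size. This shows that the change carries over in direction, since on both cores the chloro compound gives a number and the hydrogen compound reaches only a limit, but it does not show that the size carries over: the same change on two cores in this assay, an at least 1.1-fold higher number (0.07 log units; that floor lies within the scatter) from compound 1 to compound 2 and an at least 2.0-fold higher number (0.31 log units; beyond the scatter) from compound 3 to compound 4; the limit leaves it open whether they differ. The step from compound 2 to compound 4 cannot be read, so the fluoro change on the core without chloro stays unresolved, and the limit itself restricts what this series can show: the limit of > 30000 nM in this assay, at which 2 of the 4 values shown sit.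

From the compounds shown here alone, it remains open how far the loss runs on either core, and whether a group such as bromo, methoxy, an amine or a carboxylic acid on that aromatic carbon would keep a readable number. Also open, going by these compounds, is whether a longer chain in place of the methyl on the shared core would shift these values.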